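The source may report more compounds than this note shows. Statements on the series, on what has been measured and on what is new or still open speak of the compounds shown alone.

In a functional assay (aorta) with Rattus norvegicus as the target (on this read-out higher numbers stand for an effect only at larger amounts of compound and lower numbers for an effect already at smaller amounts), compound 1 (`CNC(=N)Nc1nc(-c2ccc(OC)cc2)c(-c2ccc(OC)cc2)s1`) reads 1.2 uM and compound 2 (`COc1ccc(-c2nc(/N=C(\N)N(C)C)sc2-c2ccc(OC)cc2)cc1`) reads 4.8 uM in the same test. Compound 3 (`COc1ccc(-c2nc(CNC(=O)CSc3ccccc3)sc2-c2ccc(OC)cc2)cc1`) reads 4.2 uM here, which lies within the scatter of compound 2 and is a higher number than that of compound 1. Compound 4 (`COc1ccc(-c2nc(CNC(=O)N3CCOCC3)sc2-c2ccc(OC)cc2)cc1`) differs from compound 3 in one place, with morpholin-4-yl in place of (phenylsulfanyl)methyl on a carbonyl carbon. Among the measured compounds shown here, no measured step touches that place. The only one available, on an aromatic carbon, is modest (a 4.0-fold higher number from compound 1 to compound 2 (0.60 log units; beyond the scatter)) and offers no direction for this change. In this assay no change beyond the scatter is therefore expected, and the estimated move is small (a 1.2-fold higher number from compound 3 to compound 4 (0.08 log units; within the scatter)). For compound 4 the estimated value is 5 uM (expected range 1.5 uM to 16 uM).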

Compound 4, concentration for half-maximal effect: 12 uM
The estimate for compound 4 lay 2.4-fold (0.38 log units) below the measured number; the range from low to high includes it.
By their numbers in this assay, from the lowest: compound 1; then compounds 3 and 2 (each within the scatter of the next); then compound 4.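

In this assay, among the compounds shown here, the carbonyl carbon proves sensitive to what it carries: morpholin-4-yl in place of (phenylsulfanyl)methyl gives a 2.9-fold higher number from compound 3 to compound 4 (0.46 log units; beyond the scatter), the only measured change at this place. Replacing the whole group on the aromatic carbon gives a 2.5-fold higher number from compound 2 to compound 4 (0.40 log units; beyond the scatter) and a 10-fold higher number from compound 1 to compound 4 (1.00 log units; beyond the scatter), so compound 4 has the highest number of the four. No measured evidence accounts for this shift. On these data alone, whether the phenyl ring, the sulfur or the ring nitrogen and oxygen of morpholin-4-yl drive the difference stays open, as does how a piperidin-1-yl group or a simple amine would read on that carbonyl carbon.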